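Butoxy to benzyloxy on the aryl ether arm

The compounds below may be only part of what the source reports. "The series", "measured", "known", "first", "only" and "open" are said of these compounds alone.

Measured so far:
compound 1, `CC(C(=O)NCc1ccc(C(C)(C)C)nc1SCCCN(C)C)c1ccc(NS(C)(=O)=O)c(F)c1`, gives 51.8 nM in an assay on cells for antagonist activity at transient receptor potential cation channel subfamily V member 1 (Homo sapiens), read by FLIPR and calcium flux, with a stated time of 6 min; on this read-out higher numbers stand for weaker inhibition and lower numbers for stronger inhibition.
compound 2, `CCCCOc1cc(C(C)(C)C)ccc1CNC(=O)C(C)c1ccc(NS(C)(=O)=O)c(F)c1`, gives 1.4 nM in this assay.

Compound 2 holds the lower of the two numbers; compound 1 sits well above it, a gap beyond the scatter. Compound 3, `CC(C(=O)NCc1ccc(C(C)(C)C)cc1OCc1ccccc1)c1ccc(NS(C)(=O)=O)c(F)c1`, differs from compound 2 by phenyl in place of propyl on a saturated chain carbon bound to an oxygen on an aromatic ring, that is butoxy to benzyloxy. Among the measured compounds shown here, no measured pair shows this change, so the size of the step in this assay is not known from the data. A small loss, or none beyond the scatter, is expected, as the step of a 2.1-fold higher number from compound 2 to compound 3 (0.33 log units; beyond the scatter). Compound 3 is expected near 3 nM, within a range from 0.7 nM to 15 nM.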

Compound 3, inhibition constant: 2.9 nM
Compound 3: middle estimate off by 1.0-fold (0.01 log units), on the high side; the measured number falls inside the stated range.
By their numbers in this assay, from the lowest: compound 2; then compound 3; then compound 1.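

In this assay the change from butoxy to benzyloxy brings a 2.1-fold higher number from compound 2 to compound 3 (0.32 log units; beyond the scatter) and thus a modest loss. On a saturated chain carbon bound to an oxygen on an aromatic ring, phenyl can therefore take the place of propyl, and a six-membered aromatic ring of carbon only costs little at this position. Nothing measured on these compounds accounts for the size of this step.
From the compounds shown here alone, whether a substituted benzyl, a longer alkyl chain or a terminal amine on this ether arm would give a lower or higher number remains open. So does whether the same change would give a similar step on the core of compound 1.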